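This account rests on a few compounds, and the source may have more. Where it says the series, first, only, none or still open, it means among the compounds named here.

Of the compounds shown here, three sharing one core have been tested in a functional assay on HT-29 cells (Homo sapiens) for cytotoxicity, with a stated time of 4 h; a lower number here means a stronger inhibitor, a higher number a weaker inhibitor. Compound 1 `CN(C)CCNc1n[n+]([O-])c2ccccc2[n+]1[O-]` gives 700 nM in this assay. Compound 2 `[O-][n+]1nc(NCCN2CCCCC2)[n+]([O-])c2ccccc21` differs from compound 1 by piperidin-1-yl in place of dimethylamino on a saturated chain carbon, two bonds along the chain from a nitrogen on an aromatic ring. In this assay compound 2 gives 1800 nM, which is a 2.6-fold higher number from compound 1 to compound 2 (0.41 log units; beyond the scatter). Compound 3 `CCc1ccc2c(c1)[n+]([O-])c(NCCN(C)C)n[n+]2[O-]` differs from compound 1 in its core, by ethyl in place of hydrogen on an aromatic carbon. In this assay compound 3 gives 1300 nM, which is a 1.9-fold higher number from compound 1 to compound 3 (0.27 log units; within the scatter), so the two values cannot be told apart with confidence.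

Compound 4 `CCc1ccc2c(c1)[n+]([O-])c(NCCN1CCCCC1)n[n+]2[O-]` has not yet been measured in this assay. It carries the same core as compound 3 and differs from it by piperidin-1-yl in place of dimethylamino on a saturated chain carbon, two bonds along the chain from a nitrogen on an aromatic ring. This is the same change that separates compound 2 from compound 1, and it occurs twice among these compounds. The expectation for compound 4 rests on that earlier pair: the step from compound 3 to compound 4 is expected to be a 2.6-fold higher number from compound 3 to compound 4 (0.42 log units; beyond the scatter), because the same change once gave a 2.6-fold higher number from compound 1 to compound 2 (0.41 log units; beyond the scatter). Compound 4 is thus estimated to give about 3400 nM, most likely between 1500 nM and 7500 nM.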

Compound 4, half-maximal inhibitory concentration: 1500 nM
Beside the measured number, compound 4's estimate is 2.3-fold (0.36 log units) above it, and the stated range covers the measured number.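

In this assay, putting piperidin-1-yl in place of dimethylamino on the core that carries ethyl gives a 1.2-fold higher number from compound 3 to compound 4 (0.06 log units; within the scatter), a step too small to separate the two compounds, yet the gap to the same change on the core without ethyl is no larger than two such steps can show by chance: the same change on two cores in this assay, a 2.6-fold higher number (0.41 log units; beyond the scatter) from compound 1 to compound 2 and a 1.2-fold higher number (0.06 log units; within the scatter) from compound 3 to compound 4, 2.2-fold (0.35 log units) apart, within the scatter of two such steps. Read the other way, adding ethyl to the core of the piperidin-1-yl compounds gives a 1.2-fold lower number from compound 2 to compound 4 (0.08 log units; within the scatter), and this step likewise cannot be told apart from its earlier counterpart: the same change on two cores in this assay, a 1.9-fold higher number (0.27 log units; within the scatter) from compound 1 to compound 3 and a 1.2-fold lower number (0.08 log units; within the scatter) from compound 2 to compound 4, 2.2-fold (0.35 log units) apart, within the scatter of two such steps. Within the data shown here, this shows no measurable difference in how either change behaves on the two cores, but it does not prove that the changes carry over unaltered, since each comparison rests on only two steps in a single assay.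

The compounds shown leave open whether another amine, such as morpholin-4-yl, or a longer chain would behave the same way on both cores. They also leave open whether a group other than ethyl, such as methoxy, would fit this picture.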